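The source may report more compounds than this note shows. Statements on the series, on what has been measured and on what is new or still open speak of the compounds shown alone.

Measured in a functional assay on OVCAR-3 cells (Homo sapiens) for antiproliferative activity, read by MTT assay, with a stated time of 24 h; on this read-out higher numbers stand for weaker inhibition and lower numbers for stronger inhibition:
- compound 1 `Cc1ccccc1NNC(=O)c1ccc(NS(=O)(=O)c2cnc(O)nc2O)cc1`: > 20000 nM, a limit
- compound 2 `O=C(NNc1cccc(Cl)c1)c1ccccc1NS(=O)(=O)c1cnc(O)nc1O`: 5520 nM
- compound 3 `Cc1ccccc1C(=O)NNC(=O)c1ccc(NS(=O)(=O)c2cnc(O)nc2O)cc1`: > 20000 nM, a limit

Among the measured compounds shown here, compound 2 is the only compound with a number. The other two stand at the limit of > 20000 nM in this assay, at which 2 of the 3 values shown sit.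

Compound 4 `O=C(NNC(=O)c1ccccc1NS(=O)(=O)c1cnc(O)nc1O)c1ccccc1F` differs from compound 2 by (2-fluorophenyl)carbonyl in place of 3-chlorophenyl on an amine nitrogen.

For the measured compounds named here, the one measured step of this kind is a step that the two limits leave unreadable from compound 1 to compound 3, so no size can be taken from it. Compound 3 carries a carbonyl on that nitrogen, and its > 20000 nM is a limit. On that weak basis, weaker inhibition is expected in this assay, with the expected change being a 1.8-fold higher number from compound 2 to compound 4 (0.26 log units; within the scatter). The estimate for compound 4 is 10000 nM, with an expected range of 3000 nM to 20000 nM.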

Compound 4, half-maximal inhibitory concentration: 15300 nM
For compound 4 the middle estimate is 1.5-fold (0.18 log units) below the measured one; measured number inside the range.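

On this amine nitrogen, a group carrying a carbonyl now gives a readable step in this assay, and it goes toward weaker inhibition (a 2.8-fold higher number from compound 2 to compound 4 (0.44 log units; beyond the scatter)). The earlier step on this nitrogen cannot be read, because compound 1 and compound 3 both sit at a limit: the limit of > 20000 nM in this assay, at which 2 of the 4 values shown sit.

The step joins two changes, the added carbonyl and the swap of 3-chlorophenyl for a 2-fluorophenyl ring, and the compounds shown do not separate them. Going by these compounds, it remains open how (3-chlorophenyl)carbonyl or an unsubstituted benzoyl group on that nitrogen would read.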